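Methyl for hydrogen on a ring-bound nitrogen: series notes

A few compounds are considered here, and "the series" means these few. Any claim that something is new, unique, unknown or untested is made for them only; others in the source may bear on it.

Values measured in a functional assay on cells (Mus musculus) for cytotoxicity, read by MTT assay, with a stated time of 24 h, tested at 1 uM; a higher number here means a stronger effect of the compound at the concentration tested, a lower number a weaker effect:
Compound 1, `COc1cc(/C=N/Nc2nc3ccccc3s2)cc(OC)c1OC`, gives 4%.
Compound 2, `COc1cc(/C=N/N(C)c2nc3ccccc3s2)cc(OC)c1OC`, gives 7%.
Compound 3, `COc1cc(/C=N/Nc2nc3ccccc3s2)ccc1O`, gives 44%.

Compound 1 and compound 2 share one core and differ only by methyl in place of hydrogen on a nitrogen on an aromatic ring. That change made a number 3 percentage points higher from compound 1 to compound 2 (within the scatter). Compound 3 carries a different core; how the core of compound 3 differs from the core of compound 1 is not broken down here. In this assay compound 3 stands highest of the three, and its gaps to compound 2 and to compound 1 are both beyond the scatter.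

Compound 4, `COc1cc(/C=N/N(C)c2nc3ccccc3s2)ccc1O`, is not yet measured. It relates to compound 3 as compound 2 relates to compound 1: the change is methyl in place of hydrogen on a nitrogen on an aromatic ring, the same change at the same kind of place, here on the core of compound 3. Among the four compounds it occurs twice, and only one instance is measured, so nothing beyond those two compounds can be claimed about it.

The expectation for compound 4 rests on that one measured instance, the step of a number 3 percentage points higher from compound 1 to compound 2 (within the scatter), which lay within the scatter. The expected step is accordingly no change at the digits printed from compound 3 to compound 4 (within the scatter). Compound 4 is therefore estimated at 44%, with an expected range from 27% to 60%.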

Compound 4, a percentage reported as activity, at one concentration (the size of the read-out at that concentration, not a potency): 96%
For compound 4 the middle estimate is 52 percentage points below the measured one, and the stated range ends below it.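

In this assay, methyl in place of hydrogen on a nitrogen on an aromatic ring gave a number 52 percentage points higher from compound 3 to compound 4 (beyond the scatter), so on the core of compound 3 this change is far from the near-silent step seen on the core of compound 1. These two pairs do not show which feature of the cores goes with the different outcomes, nor any mechanism behind them, and each core is represented by a single pair read at one concentration, which says nothing about potency or about any core beyond these two. For this series, then, the result of this change on one core cannot be taken as a guide to its result on the other, and the four compounds support nothing wider than that: the same change on two cores in this assay, a number 3 percentage points higher (within the scatter) from compound 1 to compound 2 and a number 52 percentage points higher (beyond the scatter) from compound 3 to compound 4, 49 percentage points apart, beyond the scatter of two such steps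

The compounds shown leave open whether the large step on the core of compound 3 is specific to methyl or would also appear with ethyl, a longer chain or an acetyl group on the same nitrogen. They also leave open how that step would behave on further cores, for instance ones carrying an amine or a carboxylic acid in place of the hydroxyl group of compound 4.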